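This account rests on a few compounds, and the source may have more. Where it says the series, first, only, none or still open, it means among the compounds named here.

The measured compounds are compound 1 `CC(=O)Nc1cc(Oc2ccc(NC(=O)Nc3ccc(CN4CCN(C)CC4)c(C(F)(F)F)c3)cc2)ncn1`, which in a functional assay on BaF3 cells (Mus musculus) for inhibition, read by CCK-8 assay, with a stated time of 72 h (on this read-out higher numbers stand for weaker inhibition of growth and lower numbers for stronger inhibition of growth), gives 50 nM; compound 2 `Cc1ccc(NC(=O)Nc2ccc(Oc3cc(N)ncn3)cc2)cc1C(F)(F)F`; and compound 3 `Cc1ccc(NC(=O)Nc2ccc(Oc3cc(/N=C/N(C)C)ncn3)cc2)cc1C(F)(F)F`, which in this assay gives 6610 nM. For compound 2 this assay reports only a limit, > 10000 nM.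

Compound 3 stands highest of the two numbers shown; the nearest, compound 1, lies far lower, well beyond the scatter. Compound 4 `C=CC(=O)Nc1cc(Oc2ccc(NC(=O)Nc3ccc(C)c(C(F)(F)F)c3)cc2)ncn1` is not yet measured. It differs from compound 3 in one place: a group of 5 heavy atoms (3 carbon, 1 nitrogen, 1 oxygen; no ring) in place of a group of 5 heavy atoms (3 carbon, 2 nitrogen; no ring), on an aromatic carbon. Of the measured steps only an at least 1.5-fold lower number from compound 2 to compound 3 (0.17 log units; that floor lies within the scatter) touches the same position, and it starts from a value that is only a limit (the limit of > 10000 nM in this assay, at which 1 of the 3 values shown sits), so it fixes no size. Compound 1 carries an acylamino group at that position and gives 50 nM, though compound 1 and compound 4 differ elsewhere too, and no step between them is shown. On that basis the (vinylcarbonyl)amino group in compound 4 is expected to bring a large drop, a 33-fold lower number from compound 3 to compound 4 (1.52 log units; beyond the scatter), in this assay. Compound 4 is estimated at 200 nM, between 30 nM and 1500 nM.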

Compound 4, concentration for 50% growth inhibition: 1940 nM
For compound 4 the middle estimate is 9.7-fold (0.99 log units) below the measured one; the whole stated range lies below it.
By their numbers in this assay, from the lowest: compound 1; then compound 4; then compound 3. At a limit, above all of these: compound 2.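

In this assay, among the compounds shown here, the (vinylcarbonyl)amino group, on the aromatic carbon next to the ring nitrogen, gives the first step of readable size at this position: a 3.4-fold lower number from compound 3 to compound 4 (0.53 log units; beyond the scatter), modest but beyond the scatter. Placing vinylcarbonyl on the free amino nitrogen also moves the number clearly, with an at least 5.1-fold lower number from compound 2 to compound 4 (0.71 log units; beyond the scatter), whereas the earlier step at this position had a floor within the scatter. That second step gives only a floor, since compound 2 reports a limit and not a number: the limit of > 10000 nM in this assay, at which 1 of the 4 values shown sits.

The compounds shown leave open whether a propanoylamino group, which lacks the vinyl double bond, or a longer acyl chain at this position would give a number like that of compound 4. For the compounds shown here, no step links compound 4 to compound 1, so what each of their differences contributes remains unresolved.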